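This account rests on a few compounds, and the source may have more. Where it says the series, first, only, none or still open, it means among the compounds named here.

Working notes on the series. Compound 1 `O=C1Nc2cc(Br)ccc2/C1=C\c1cccc(OCc2cn(Cc3ccccc3)nn2)c1` and compound 2 `O=C1Nc2ccc(F)cc2/C1=C\c1cccc(OCc2cn(Cc3ccccc3)nn2)c1` share one core. In a functional assay on A549 cells (Homo sapiens) for inhibition, read by MTT assay, with a stated time of 48 h (on this read-out higher numbers stand for weaker inhibition and lower numbers for stronger inhibition), compound 1 gives 9600 nM. For compound 2 the result is a limit of the assay only, > 50000 nM. One of the two recorded values sits at that limit (the limit of > 50000 nM in this assay, at which 1 of the 2 values shown sits). Compound 3 `O=C1Nc2ccc([N+](=O)[O-])cc2/C1=C\c1cccc(OCc2cn(Cc3ccccc3)nn2)c1` remains to be measured. It differs from compound 2 by nitro in place of fluoro on an aromatic carbon. Going by the values given here, no measured step of this kind exists, so the expected step of an at least 1.6-fold lower number from compound 2 to compound 3 (0.22 log units; that floor lies within the scatter) is tentative and leans towards stronger inhibition. Compound 3 is estimated at 30000 nM, within 8000 nM to 100000 nM.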

Compound 3, half-maximal inhibitory concentration: > 50000 nM
Compound 3 gave a limit, no number; the forecaster's own chance of this, stated with the estimate: 45%; at least 1.6-fold (0.22 log units) between middle value and limit.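

Compound 2 and compound 3 both stand only as limits, so no step between them can be read: the limit of > 50000 nM in this assay, at which 2 of the 3 values shown sit.

Going by these compounds, whether nitro in place of fluoro on this aromatic carbon changes inhibition at all remains open.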